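Extending the side chain of compound 3

The compounds below may be only part of what the source reports. "The series", "measured", "known", "first", "only" and "open" are said of these compounds alone.

Compound 1 `O=C(NCCC1CCNCC1)Nc1nc2ccc(C(=O)c3ccccc3)cc2[nH]1` reads > 30000 nM as a limit
Compound 2 `NCCCC(=O)Nc1nc2ccc(C(=O)c3ccccc3)cc2[nH]1` reads > 30000 nM as a limit
Compound 3 `O=C(CCC1CCNCC1)Nc1nc2ccc(C(=O)c3ccccc3)cc2[nH]1` reads > 30000 nM as a limit

All three readings in an ADME assay on CRL8155 cells (Homo sapiens) for cytotoxicity, read by resazurin assay, with a stated time of 72 h (a higher number here means that more compound is needed for the effect, a lower number that less compound is needed), are limits and not numbers (the limit of > 30000 nM in this assay, at which 3 of the 3 values shown sit). Compound 3 stands at its limit of > 30000 nM with no number to build on. Compound 4 `O=C(CCCC1CCNCC1)Nc1nc2ccc(C(=O)c3ccccc3)cc2[nH]1` carries one change ((piperidin-4-yl)methyl in place of piperidin-4-yl on a saturated chain carbon, two bonds along the chain from a carbonyl carbon) with (piperidin-4-yl)methyl in place of piperidin-4-yl on a saturated chain carbon, two bonds along the chain from a carbonyl carbon. The closest measured change is (a step that the two limits leave unreadable from compound 2 to compound 3) and another is (a step that the two limits leave unreadable from compound 1 to compound 3), so neither offers a size to carry over. No step beyond the scatter, in either direction, is therefore expected (a number no higher from compound 3 to compound 4 (the limit leaves the size open)). For compound 4 the estimated value is 30000 nM with an expected range from 12000 nM to 60000 nM and another limit is quite likely.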

Compound 4, half-maximal effective concentration: > 30000 nM
Compound 4 was reported as a limit (the forecaster's own chance of this, stated with the estimate: 75%); the middle value sits exactly at the limit.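

Among these compounds, compound 4 stays at a limit in this assay, as do compound 1, compound 2 and compound 3, so no step among them can be read: the limit of > 30000 nM in this assay, at which 4 of the 4 values shown sit.

What remains open is the concentration at which any of these compounds reaches the effect, and whether the side chain changes it.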